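The source may hold more compounds than are shown below. What is called first, only, known or untested is meant among the compounds shown, and "the series" means these compounds.

The compounds measured so far:
Compound 1, `Cc1cc(/C=C/C#N)cc(C)c1Oc1cc(Nc2ccc(C#N)cc2)c(N)cc1C(=O)NN`, which in a physicochemical assay for lipophilicity, read by HPLC, measured as octanol-water partition, with a stated time of 24 h, at pH 7.4 (a lower number here means a more polar compound, a higher number a more lipophilic compound), gives 2.31.
Compound 2, `Cc1cc(/C=C/C#N)cc(C)c1Oc1cc(Nc2ccc(C#N)cc2)c(N)cc1C(=O)NCCCO`, which in this assay gives 3.22.
Compound 3, `Cc1cc(/C=C/C#N)cc(C)c1Oc1cc(Nc2ccc(C#N)cc2)c(N)cc1C(=O)OCCC#N`, for which this assay reports only a limit, > 5.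

Compound 3 thus stands at the top of the set, not as a number but as a limit (the limit of > 5 in this assay, at which 1 of the 3 values shown sits). Both steps leading to it, a number at least 2.69 log units higher from compound 1 to compound 3 (beyond the scatter) and a number at least 1.78 log units higher from compound 2 to compound 3 (beyond the scatter), are large, while a number 0.91 log units higher from compound 1 to compound 2 (beyond the scatter) is modest. Compound 4, `CNC(=O)c1cc(N)c(Nc2ccc(C#N)cc2)cc1Oc1c(C)cc(/C=C/C#N)cc1C`, is not yet measured in this assay. It differs from compound 3 in one place: methylamino in place of 2-cyanoethoxy on a carbonyl carbon. The two large steps ran the opposite way, each replacing a nitrogen on the carbonyl carbon with 2-cyanoethoxy; the present change puts a nitrogen, as methylamino, back on that carbon, so compound 4 resembles compound 2 more than compound 3. The step of a number at least 1.70 log units lower from compound 3 to compound 4 (beyond the scatter) is therefore expected to be large and downward, and a number rather than a limit is expected. For compound 4 the estimate in this assay is 3.3, within a range from 2.6 to 4.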

Compound 4, partition coefficient: 2.65
Beside the measured number, compound 4's estimate is 0.65 log units above it; measured number inside the range.
By their numbers in this assay, from the lowest: compound 1; then compound 4; then compound 2. At a limit, above all of these: compound 3.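

Compound 3 holds only a limit, not a number: the limit of > 5 in this assay, at which 1 of the 4 values shown sits.

In this assay, methylamino on the carbonyl carbon gives a measured value in place of that limit, with a number at least 2.35 log units lower from compound 3 to compound 4 (beyond the scatter), so this change has a lower bound on its size but no exact figure. Among the groups that attach through nitrogen, the methylamino value lies inside the span of the two earlier numbers, with a number 0.57 log units lower from compound 2 to compound 4 (beyond the scatter) and a number 0.34 log units higher from compound 1 to compound 4 (beyond the scatter).

The compounds shown leave open how a propylamino group, a chain without the hydroxyl, would read in this assay, and so whether the chain length or the hydroxyl of the 3-hydroxypropyl group accounts for the gap to methylamino. They also leave open how a dimethylamino group, with no amide hydrogen, would read on the same carbon.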